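Swapping a sulfonyl cap for acetyl on a shared core

The compounds below may be only part of what the source reports. "The series", "measured", "known", "first", "only" and "open" are said of these compounds alone.

Measured so far:
compound 1 `Nc1cc(-c2cnc3[nH]cc(-c4ccncc4)c3c2)ccc1Cl`: 12000 nM
compound 2 `Nc1cc(NS(=O)(=O)c2ccc(F)cc2F)cc(-c2cnc3[nH]cc(-c4ccncc4)c3c2)c1`: 6600 nM
compound 3 `Nc1cncc(-c2cnc3[nH]cc(-c4ccncc4)c3c2)c1`: 5100 nM

These three compounds share one core and differ only in the ring hung from it. Their numbers in a functional assay on MCF7 cells (Homo sapiens) for cytotoxicity, read by MTT assay, with a stated time of 48 h (on this read-out lower numbers stand for stronger inhibition and higher numbers for weaker inhibition), all sit close together: compound 2 stands second highest of the three, with compound 3 nearest and compound 1 furthest, and both of those gaps are within the scatter, so no order among them can be claimed.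

The next compound keeps the core of compound 2 and alters the cap on the ring. Compound 4 `CC(=O)Nc1cc(N)cc(-c2cnc3[nH]cc(-c4ccncc4)c3c2)c1` differs from compound 2 in this way: acetyl in place of (2,4-difluorophenyl)sulfonyl on a nitrogen on an aromatic ring. A large group leaves and a much smaller one enters on the same nitrogen on an aromatic ring.

Among the measured compounds shown here, no measured pair shows what such a change does here, so the expectation rests only on the spread of the three values, which are all within the scatter of one another. Compound 4 is therefore expected to land close to compound 2, with the step of a 1.2-fold higher number from compound 2 to compound 4 (0.08 log units; within the scatter) estimated to be none beyond the scatter. For compound 4 in this assay the estimate is 8000 nM, with a range from 3000 nM to 20000 nM.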

Compound 4, half-maximal inhibitory concentration: > 30000 nM
Compound 4: no number, only a limit; the forecaster's own chance of this, stated with the estimate: 10%; middle value at least 3.7-fold (0.57 log units) away from the limit.
By their numbers in this assay, from the lowest: compounds 3, 2 and 1 (each within the scatter of the next, the first and the last beyond it). At a limit, above all of these: compound 4.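

The earlier compounds shown here offered no pair differing in one place, so they said nothing about this nitrogen; compound 2 and compound 4 supply that pair. In this assay, acetyl in place of (2,4-difluorophenyl)sulfonyl on a nitrogen on an aromatic ring gives an at least 4.5-fold higher number from compound 2 to compound 4 (0.65 log units; beyond the scatter), so what sits on this nitrogen can move the read-out beyond the scatter. The reading for compound 4 is a limit of the assay and not a number, so the step has a known lower edge but no known full size: the limit of > 30000 nM in this assay, at which 1 of the 4 values shown sits.

The swap removes the sulfonyl and the fluorinated aromatic ring together, so this one pair cannot show which of these parts accounts for the step. Caps such as methanesulfonyl, which keeps the sulfonyl without the ring, or benzoyl, which keeps a ring on a carbonyl, would pull those two parts apart, and the unsubstituted amine on the same position would show how the core behaves with no cap at all.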